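Replacing the piperidine of compound 3 with a dichloropyridinyloxy group

This account rests on a few compounds, and the source may have more. Where it says the series, first, only, none or still open, it means among the compounds named here.

Measured compounds:
compound 1, `CN(C)C(=O)/C=C/c1ccc2noc(-c3ccccc3)c2c1` — > 100000 nM
compound 2, `CNC(=O)c1ccc2noc(-c3ccccc3)c2c1` — 6830 nM
compound 3, `O=C(O)c1ccc2noc(-c3ccc(N4CCCCC4)cc3)c2c1` — 1790 nM

In an assay for inhibition of inositol hexakisphosphate kinase 3 (Homo sapiens), read by colorimetric assay, coupled enzyme assay and malachite green, with a stated time of 120 min, in the presence of a further agent that is not named here (on this read-out higher numbers stand for weaker inhibition and lower numbers for stronger inhibition), compound 1 is reported only as a limit, > 100000 nM. Compound 2 gives 6830 nM in this assay. Compound 3 gives 1790 nM, the lowest of the two numbers shown; compound 2 stands next to it, and the gap between them lies beyond the scatter. Within the data shown here, the only step measured so far, an at least 14-fold lower number from compound 1 to compound 2 (1.16 log units; beyond the scatter), concerns the carbamoyl side of the shared core and not the ring that carries the piperidine.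

Compound 4, `O=C(O)c1ccc2noc(-c3ccc(Oc4ncc(Cl)cc4Cl)cc3)c2c1`, differs from compound 3 by (3,5-dichloropyridin-2-yl)oxy in place of piperidin-1-yl on an aromatic carbon. Among the measured compounds shown here, no measured step touches that position, so there is no basis for expecting a shift in either direction beyond the scatter. Compound 4 is therefore expected to give about 1800 nM, with a range from 400 nM to 8000 nM. This estimate means a 1.0-fold higher number from compound 3 to compound 4 (0.00 log units; within the scatter), a change expected to stay close to compound 3.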

Compound 4, half-maximal inhibitory concentration: 2250 nM
Compound 4: middle estimate off by 1.3-fold (0.10 log units), on the low side; the range from low to high includes it.
By their numbers in this assay, from the lowest: compounds 3 and 4 (each within the scatter of the next); then compound 2. At a limit, above all of these: compound 1.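

At this place, on an aromatic carbon para to a large group, the step of a 1.3-fold higher number from compound 3 to compound 4 (0.10 log units; within the scatter) shows that in this assay a non-aromatic ring attached through its nitrogen and an aromatic ring attached through oxygen cannot be told apart. Among these compounds, until now, no measured step had touched this place, and this one shows that it accepts the larger (3,5-dichloropyridin-2-yl)oxy group with no change beyond the scatter. Nothing measured here bears on why these two groups read alike.

From the compounds shown here alone, it remains open how a small amine such as dimethylamino, a longer alkyl chain or a plain hydrogen at this place would read. Also open, going by these compounds, is what a methylcarbamoyl group in place of the carboxylic acid would do with either of these two groups present.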